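The compounds below may be only part of what the source reports. "The series", "measured", "known", "first", "only" and "open" are said of these compounds alone.

Of the compounds shown here, three share one core and have been measured in a physicochemical assay for solubility, read by HPLC, measured as octanol-water partition, at pH 7.4; on this read-out higher numbers stand for higher solubility and lower numbers for lower solubility. Compound 1 `Clc1ccc2c(NCCCOc3nccc(Cl)n3)ccnc2c1` gives 2190 nM. Compound 2 `Clc1ccc2c(NCCCNc3nccc(N4CCCC4)n3)ccnc2c1` gives 1250 nM. Compound 3 `Clc1ccc2c(NCCNc3nccc(Cl)n3)ccnc2c1` gives 2850 nM. Compound 2 thus stands at the low end of the three numbers: compound 1 sits within the usual scatter of it, while compound 3 sits beyond the scatter, so only the gap to compound 3 can be taken as a real difference. No pair of these compounds differs in a single place, so none of the measured steps isolates one change.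

Compound 4 `Clc1ccc2c(NCCCNc3nccc(N4CCNCC4)n3)ccnc2c1` has not been measured. It differs from compound 2 in one place: piperazin-1-yl in place of pyrrolidin-1-yl on an aromatic carbon. Among the compounds with values here, nothing among the measured compounds shows this exchange, so the expectation rests on the measured spread alone. The step from compound 2 to compound 4 in this assay is expected to be a modest rise, a 2.0-fold higher number from compound 2 to compound 4 (0.30 log units; within the scatter), possibly not beyond the scatter. Compound 4 is therefore expected to give about 2500 nM, with a range from 1200 nM to 5500 nM.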

Compound 4, solubility: 750 nM
Compound 4: middle estimate off by 3.3-fold (0.52 log units), on the high side; measured number below the stated range.
By their numbers in this assay, from the lowest: compounds 4, 2, 1 and 3 (each within the scatter of the next, the first and the last beyond it).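

At this position, on an aromatic carbon of the six-membered aromatic ring with 2 nitrogen, the study now has its first single-place step in this assay: piperazin-1-yl in place of pyrrolidin-1-yl gives a 1.7-fold lower number from compound 2 to compound 4 (0.22 log units; within the scatter) and so leaves the two compounds indistinguishable. The read-out therefore does not separate these groups, although the entering one is a six-membered ring with 2 hetero atoms and a hydrogen-bond donor, and the leaving one a five-membered ring with 1 hetero atom and no donor. No measurement shown accounts for this step.

Going by these compounds, whether another group at this position, such as a morpholine or a carboxylic acid, would move the number beyond the scatter remains open. On these data alone, it is also open whether the same exchange would read alike on a longer chain.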